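This account rests on a few compounds, and the source may have more. Where it says the series, first, only, none or still open, it means among the compounds named here.

Measured in a functional assay on T-24 cells (Homo sapiens) for antiproliferative activity, read by MTT assay, with a stated time of 48 h; a higher number here means a weaker inhibitor, a lower number a stronger inhibitor:
- compound 1 `O=C(Nc1ccc(Cl)cc1)Nc1cccc(CNc2nccnc2Cl)c1`: 5470 nM
- compound 2 `Cc1cccc(NC(=O)Nc2cccc(CNc3nccnc3Cl)c2)c1`: 9570 nM

Only these two compounds have been measured so far, and their values lie within the scatter of each other. Compound 2, at 9570 nM, therefore cannot be separated from compound 1 in this assay.

The next compound is compound 3 `Cc1ccccc1NC(=O)Nc1cccc(CNc2nccnc2Cl)c1`, which has the same atoms as compound 2, joined differently: 2-methylphenyl in place of 3-methylphenyl on an amide-type nitrogen. In words, 2-methylphenyl stands in place of 3-methylphenyl on an amide-type nitrogen.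

Among the measured compounds shown here, one measured step bears on this change. It is a swap on that same kind of nitrogen, a 1.7-fold higher number from compound 1 to compound 2 (0.24 log units; within the scatter), and it stays within the scatter. For the measured compounds named here, it exchanges one group for another, however, and no measured pair shows what happens when only the methyl position differs. The evidence is therefore thin, and it gives no direction. No step beyond the scatter is expected in this assay, and the expected step is a 1.1-fold lower number from compound 2 to compound 3 (0.03 log units; within the scatter). For compound 3 the estimated value is 9000 nM, with an expected range of 3500 nM to 23000 nM.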

Compound 3, half-maximal inhibitory concentration: 13600 nM
Beside the measured number, compound 3's estimate is 1.5-fold (0.18 log units) below it; the measured number falls inside the stated range.
By their numbers in this assay, from the lowest: compounds 1, 2 and 3 (each within the scatter of the next, the first and the last beyond it).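

In this assay, among the compounds shown here, the first pair that differs only in the methyl position on the phenyl group at the amide-type nitrogen shows a 1.4-fold higher number from compound 2 to compound 3 (0.15 log units; within the scatter) and so does not separate 2-methylphenyl from 3-methylphenyl at this place. For the compounds shown here, the exchange of 4-chlorophenyl for 2-methylphenyl gives a 2.5-fold higher number from compound 1 to compound 3 (0.40 log units; beyond the scatter) and is the first step at this nitrogen to pass beyond the scatter, though only modestly, whereas the earlier exchange of 4-chlorophenyl for 3-methylphenyl stayed within it. Nothing available explains either step or accounts for the difference among these three groups.

The compounds shown leave open how 4-methylphenyl would compare with 4-chlorophenyl, a pair that would isolate the exchange of methyl for chlorine at one ring position, and how 2-chlorophenyl would compare with 2-methylphenyl. Going by these compounds, all three compounds also keep the rest of the core unchanged, so it remains open what an unsubstituted phenyl or a cyclohexyl group would do at this nitrogen, and what any change elsewhere in the core would do.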